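The source may hold more compounds than are shown below. What is called first, only, known or untested is meant among the compounds shown, and "the series" means these compounds.

Values in a functional assay on KYSE-410 cells (Homo sapiens) for antiproliferative activity, read by MTT assay, with a stated time of 72 h; a higher number here means a weaker inhibitor, a lower number a stronger inhibitor:
- compound 1 `O=C(Nc1cc(F)cc(F)c1)c1cc(=O)[nH]c2cc(F)ccc12`: > 20000 nM (a limit of the assay, not a number)
- compound 2 `O=C(Nc1cc(F)cc(F)c1)c1cc(=O)[nH]c2cc(Cl)ccc12`: 11000 nM
- compound 3 `O=C(Nc1cc(F)cc(F)c1)c1cc(=O)[nH]c2cc(C(F)(F)F)ccc12`: 17900 nM

In this assay compound 3 gives 17900 nM and stands level with compound 2: a 1.6-fold higher number from compound 2 to compound 3 (0.21 log units; within the scatter). Compound 4 `O=C(Nc1cc(F)cc(F)c1)c1cc(=O)[nH]c2cc(O)ccc12` carries hydroxy in place of trifluoromethyl on an aromatic carbon. The measured steps at this carbon are small: an at least 1.8-fold lower number from compound 1 to compound 2 (0.25 log units; that floor lies within the scatter), and an at least 1.1-fold lower number from compound 1 to compound 3 (0.04 log units; that floor lies within the scatter). Both of these rest on the limit of compound 1. Going by the values given here, no measured compound carries hydroxy, so the guide is weak, and no step beyond the scatter is expected. The expected change is a 1.1-fold higher number from compound 3 to compound 4 (0.05 log units; within the scatter). Compound 4 is estimated at 20000 nM, with an expected range of 9000 nM to 45000 nM.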

Compound 4, half-maximal inhibitory concentration: > 20000 nM
Compound 4 gave a limit, no number (the forecaster's own chance of this, stated with the estimate: 45%); the middle value lies on the limit itself.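

Hydroxy, the one group at this aromatic carbon with a hydrogen-bond donor, leaves compound 4 at a limit, not a number, in this assay: the limit of > 20000 nM in this assay, at which 2 of the 4 values shown sit. From the compounds shown here alone, the steps to it are only floors, an at least 1.1-fold higher number from compound 3 to compound 4 (0.04 log units; that floor lies within the scatter) and an at least 1.8-fold higher number from compound 2 to compound 4 (0.25 log units; that floor lies within the scatter), so their true size stays unknown. The step between compound 1 and compound 4 cannot be read, as both values are limits.

Still open, going by these compounds, is whether any group at this carbon moves the value beyond the scatter. An amine or a methoxy group here would bear on that question.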